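Halogen series on the shared core: bromo to methyl

A few compounds are considered here, and "the series" means these few. Any claim that something is new, unique, unknown or untested is made for them only; others in the source may bear on it.

Measured in a functional assay on HeLa cells (Homo sapiens) for antiproliferative activity, read by MTT assay, with a stated time of 48 h; on this read-out higher numbers stand for weaker inhibition and lower numbers for stronger inhibition:
- compound 1 `Fc1ccc2[nH]c(-c3cn(-c4ccccc4)nc3-c3ccccc3)nc2c1`: 3610 nM
- compound 2 `Clc1ccc2[nH]c(-c3cn(-c4ccccc4)nc3-c3ccccc3)nc2c1`: 3480 nM
- compound 3 `Brc1ccc2[nH]c(-c3cn(-c4ccccc4)nc3-c3ccccc3)nc2c1`: 1760 nM

Compound 3 stands at 1760 nM. Only its gap to the fluoro compound lies beyond the scatter, at a 2.1-fold lower number from compound 1 to compound 3 (0.31 log units; beyond the scatter). Its gap to the chloro compound does not, at a 2.0-fold lower number from compound 2 to compound 3 (0.30 log units; within the scatter). The remaining step, a 1.0-fold lower number from compound 1 to compound 2 (0.02 log units; within the scatter), shows no change between the two lighter halogens.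

Compound 4 `Cc1ccc2[nH]c(-c3cn(-c4ccccc4)nc3-c3ccccc3)nc2c1` carries methyl in place of bromo on an aromatic carbon, with the rest of the structure unchanged: methyl in place of bromo on an aromatic carbon. Among the measured compounds shown here, no measured step involves methyl, so the three halogen steps bear on this change only indirectly. All three are small, and the largest is a 2.1-fold lower number from compound 1 to compound 3 (0.31 log units; beyond the scatter). In this assay, a step of similar size towards a higher number is therefore expected, close to the edge of the scatter. The expected step is a 1.7-fold higher number from compound 3 to compound 4 (0.23 log units; within the scatter). Compound 4 is estimated at 3000 nM, with an expected range of 1400 nM to 6500 nM.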

Compound 4, half-maximal inhibitory concentration: 6560 nM
For compound 4 the middle estimate is 2.2-fold (0.34 log units) below the measured one; the whole stated range lies below it.
By their numbers in this assay, from the lowest: compounds 3, 2, 1 and 4 (each within the scatter of the next, the first and the last beyond it).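

In this assay, this position now shows its largest single-group step, a 3.7-fold higher number from compound 3 to compound 4 (0.57 log units; beyond the scatter), so replacing bromo with methyl matters more here than any exchange among the halogens shown. Methyl is resolved from bromo alone, since the steps to it from the lighter halogens, a 1.9-fold higher number from compound 2 to compound 4 (0.28 log units; within the scatter) and a 1.8-fold higher number from compound 1 to compound 4 (0.26 log units; within the scatter), do not separate it from chloro or fluoro. Nothing available accounts for the gap between bromo and methyl at this position.

Going by these compounds, whether an amine, a methoxy group, a carboxylic acid or a longer chain at this position would fall nearer compound 3 or compound 4 remains open. On these data alone, it is also open whether the step from bromo to methyl would keep its size on a core carrying other groups elsewhere.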